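Swapping Fluoro for Amino on a Boron-Containing Chalcone

The source may hold more compounds than are shown below. What is called first, only, known or untested is meant among the compounds shown, and "the series" means these compounds.

Compound 3 `O=C(/C=C/c1ccc2c(c1)B(O)OC2)c1cccc(F)c1` gives the lowest number of the three measured compounds in a functional assay on SK-OV-3 cells (Homo sapiens) for cytotoxicity, read by MTT assay, with a stated time of 48 h (on this read-out higher numbers stand for weaker inhibition and lower numbers for stronger inhibition), at 4800 nM. Compound 1 `O=C(/C=C/c1ccc2c(c1)B(O)OC2)c1ccco1` gives 20700 nM in this assay, and compound 2 `Cn1cccc1C(=O)/C=C/c1ccc2c(c1)B(O)OC2` gives 93600 nM. All measured steps exchange the group on the carbonyl carbon: a 4.3-fold lower number from compound 1 to compound 3 (0.63 log units; beyond the scatter), a 4.5-fold higher number from compound 1 to compound 2 (0.66 log units; beyond the scatter) and a 20-fold lower number from compound 2 to compound 3 (1.29 log units; beyond the scatter). Compound 4 `Nc1cccc(C(=O)/C=C/c2ccc3c(c2)B(O)OC3)c1` differs from compound 3 in one place: amino in place of fluoro on an aromatic carbon. For the measured compounds named here, no measured step exchanges a substituent on that ring, so the known steps bear on it only by showing that changes in that region move the number modestly. The step from compound 3 to compound 4 is therefore expected to be small, a 1.7-fold higher number from compound 3 to compound 4 (0.22 log units; within the scatter), with no clear direction. Compound 4 is estimated at 8000 nM, within a range from 2000 nM to 32000 nM.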

Compound 4, half-maximal inhibitory concentration: 7400 nM
The estimate for compound 4 lay 1.1-fold (0.03 log units) above the measured number, and the stated range covers the measured number.
By their numbers in this assay, from the lowest: compounds 3 and 4 (each within the scatter of the next); then compound 1; then compound 2.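

In this assay the exchange of fluoro for amino on the phenyl ring gives a 1.5-fold higher number from compound 3 to compound 4 (0.19 log units; within the scatter) and so does not separate the two groups. The 3-aminophenyl group keeps the standing of 3-fluorophenyl on the carbonyl carbon, with a 2.8-fold lower number from compound 1 to compound 4 (0.45 log units; beyond the scatter) against furan-2-yl and a 13-fold lower number from compound 2 to compound 4 (1.10 log units; beyond the scatter) against 1-methyl-1H-pyrrol-2-yl.

Going by these compounds, whether a carboxylic acid or a longer chain on this ring would hold the number stays open. What lies behind these numbers also remains unexplained, with no supporting measurement at hand.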